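Formyl in place of amino on the shared core

A few compounds are considered here, and "the series" means these few. Any claim that something is new, unique, unknown or untested is made for them only; others in the source may bear on it.

In a functional assay on OCI-AML2 cells (Homo sapiens) for antiproliferative activity, read by WST assay, with a stated time of 3 days (on this read-out higher numbers stand for weaker inhibition and lower numbers for stronger inhibition), compound 2 `[N-]=[N+]=Nc1c(F)c(=O)[nH]c(=O)n1[C@@H]1O[C@H](CO)[C@@H](O)[C@H]1O` gives 700 nM and compound 3 `Nc1c(F)c(=O)[nH]c(=O)n1[C@@H]1O[C@H](CO)[C@@H](O)[C@H]1O` gives 900 nM. Compound 1 `O=c1[nH]c(=O)n([C@@H]2O[C@H](CO)[C@@H](O)[C@H]2O)c(I)c1F` reads > 50000 nM, which is a limit of the assay. Compound 3 thus sits level with compound 2, and no measured number in the series separates them.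

Compound 4 `O=Cc1c(F)c(=O)[nH]c(=O)n1[C@@H]1O[C@H](CO)[C@@H](O)[C@H]1O` departs from compound 3 at one place: formyl in place of amino on an aromatic carbon. Within the data shown here, no measured compound carries formyl, so the evidence is indirect. Two large steps act at this same carbon, an at least 71-fold lower number from compound 1 to compound 2 (1.85 log units; beyond the scatter) and an at least 55-fold lower number from compound 1 to compound 3 (1.74 log units; beyond the scatter), so the group there can matter greatly. By contrast, a 1.3-fold higher number from compound 2 to compound 3 (0.11 log units; within the scatter) stays within the scatter. With a group new to the series, a moderate move to a higher number is expected, smaller than those two steps but beyond the scatter. The expected step, an estimate, is a 4.4-fold higher number from compound 3 to compound 4 (0.65 log units; beyond the scatter). For compound 4 the estimated value in this assay is 4000 nM, with an expected range of 500 nM to 40000 nM.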

Compound 4, half-maximal inhibitory concentration: 700 nM
Compound 4: middle estimate off by 5.7-fold (0.76 log units), on the high side, and the stated range covers the measured number.
By their numbers in this assay, from the lowest: compounds 2, 4 and 3 (each within the scatter of the next). At a limit, above all of these: compound 1.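

In this assay formyl reads level with the two other groups on this carbon, with a 1.3-fold lower number from compound 3 to compound 4 (0.11 log units; within the scatter) and no change at the digits printed from compound 2 to compound 4 (within the scatter) both within the scatter. Amino brings a hydrogen-bond donor and formyl brings none, so among compound 2, compound 3 and compound 4 a donor at this carbon is not needed to hold this level. Iodo in compound 1 remains the only group apart, and an at least 71-fold lower number from compound 1 to compound 4 (1.85 log units; beyond the scatter) gives a bound rather than a size, since the value of compound 1 is a limit: the limit of > 50000 nM in this assay, at which 1 of the 4 values shown sits.

From the compounds shown here alone, whether this level holds for a carboxylic acid, a hydroxymethyl group or a longer chain on this carbon stays open. So does whether chloro or bromo reads with iodo or with the other three groups.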